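Naphthyl and tolyl aryl variants on a methylated bicyclic core

The source may report more compounds than this note shows. Statements on the series, on what has been measured and on what is new or still open speak of the compounds shown alone.

Measured so far:
compound 1, `Cc1cc(C)c2c(O)cc(-c3cccc4ccccc34)nc2n1`: 191 nM
compound 2, `Cc1cccc(-c2cc(O)c3cc(C)cnc3n2)c1`: < 10 nM
compound 3, `Cc1cc(C)c2c(O)cc(-c3ccc4ccccc4c3)nc2n1`: 2950 nM

In a functional assay on MDA-MB-435 cells (Homo sapiens) for antiproliferative activity (on this read-out higher numbers stand for weaker inhibition of growth and lower numbers for stronger inhibition of growth), compound 3 gives 2950 nM, the highest of the two numbers in hand. Its nearest neighbour is compound 1, which in this assay gives 191 nM, a gap well beyond the scatter. In this assay compound 2 gives a value that is a limit of the assay, < 10 nM. Note that the limit of < 10 nM in this assay, at which 1 of the 3 values shown sits, holds one of the three values shown, so it is a bound and not a number.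

Compound 4, `Cc1ccnc2nc(-c3ccc4ccccc4c3)cc(O)c12`, has not yet been measured in this assay. It differs from compound 3 in one place: hydrogen in place of methyl on an aromatic carbon. The change removes a single carbon on the shared core of compound 3 and leaves the aryl group untouched. Within the data shown here, since no measured pair shows the effect of this particular methyl, the step from compound 3 to compound 4 is expected to be small, within the scatter, and the estimate for compound 4 is 2500 nM (range 600 nM to 9000 nM), meaning an expected step of a 1.2-fold lower number from compound 3 to compound 4 (0.07 log units; within the scatter).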

Compound 4, concentration for 50% growth inhibition: 204 nM
Estimate against measurement, compound 4: 12-fold (1.09 log units) above, and the stated range ends above it.
By their numbers in this assay, from the lowest: compounds 1 and 4 (each within the scatter of the next); then compound 3. At a limit, below all of these: compound 2.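

In this assay, the methyl next to the ring nitrogen turns out to matter: hydrogen in its place gives a 14-fold lower number from compound 3 to compound 4 (1.16 log units; beyond the scatter), so this single carbon on the shared core is not a silent position. Among these compounds, this is the first pair that differs in one place, and so the first direct reading of any change on the core, which the earlier compounds could not give. Nothing in hand bears on why the number moves.

Among the compounds shown here, whether the same step would appear with an aryl group other than the one shared by this pair stays open. So does the outcome of putting an ethyl chain, an amine or a methoxy group on this aromatic carbon in place of the methyl.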